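Replacing a cyclopropyl amide with a bulkier ring

The source may report more compounds than this note shows. Statements on the series, on what has been measured and on what is new or still open speak of the compounds shown alone.

Among the compounds with values here, compound 2 `Cn1cc(-c2nn(Cc3ccc(C(=O)NC4CC4)cc3)c(=O)c3ccccc23)cn1` is one of two compounds measured in a functional assay on A549 cells (Homo sapiens) for antiproliferative activity, read by MTT assay, with a stated time of 72 h; a higher number here means a weaker inhibitor, a lower number a stronger inhibitor. In this assay compound 2 gives 51200 nM, and compound 1 `Cn1cc(-c2nn(Cc3ccc(C(=O)N4CCCCC4)cc3)c(=O)c3ccccc23)cn1` gives 67400 nM; the two numbers sit within the scatter of each other, so neither can be called stronger. Within the data shown here, the only change recorded so far, a 1.3-fold lower number from compound 1 to compound 2 (0.12 log units; within the scatter), sits on the same amide-type nitrogen as the new change and was too small to count. Compound 3 `Cn1cc(-c2nn(Cc3ccc(C(=O)NC4CC(C)(C)N([O])C(C)(C)C4)cc3)c(=O)c3ccccc23)cn1` carries a group of 11 heavy atoms (9 carbon, 1 nitrogen, 1 oxygen; one six-membered non-aromatic ring with 1 hetero atom) in place of a group of 3 heavy atoms (3 carbon; one three-membered non-aromatic ring of carbon only), on an amide-type nitrogen. Among the measured compounds shown here, only the step from compound 1 to compound 2 bears on this, and it showed nothing beyond the scatter, so a step of about a 1.3-fold lower number from compound 2 to compound 3 (0.11 log units; within the scatter) is expected, which is no clear move in either direction. On that basis compound 3 is estimated to give about 40000 nM in this assay, within a range from 10000 nM to 150000 nM.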

Compound 3, half-maximal inhibitory concentration: 37300 nM
Beside the measured number, compound 3's estimate is 1.1-fold (0.03 log units) above it; the measured number falls inside the stated range.
By their numbers in this assay, from the lowest: compounds 3, 2 and 1 (each within the scatter of the next).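

In this assay there is a 1.4-fold lower number from compound 2 to compound 3 (0.14 log units; within the scatter) and also a 1.8-fold lower number from compound 1 to compound 3 (0.26 log units; within the scatter) for the two changes at this amide. This shows that a much larger group, the one of 11 heavy atoms with its six-membered non-aromatic ring, can replace cyclopropyl on the amide-type nitrogen without a readable shift, so all three compounds remain level within the scatter. No supporting measurement is available to explain this result.

On these data alone, it remains open whether the oxygen on the ring nitrogen of compound 3 contributes anything, which a matching ring carrying a plain amine nitrogen could test. As far as these compounds go, it is also open whether a carboxylic acid or a longer alkyl chain on this amide nitrogen would move the number beyond the scatter.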